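The compounds below may be only part of what the source reports. "The series", "measured", "known", "first", "only" and "open" are said of these compounds alone.

Compound 3 `N#CC1CN1C(=O)Nc1ccccc1` is the unsubstituted member of this small set. In a functional assay on A-375 cells (Homo sapiens) for inhibition (a higher number here means a weaker inhibitor, a lower number a stronger inhibitor), compound 3 gives 11000 nM. Compound 2 `CCOC(=O)c1ccc(NC(=O)N2CC2C#N)cc1` gives 5800 nM, and the step of a 1.9-fold higher number from compound 2 to compound 3 (0.28 log units; within the scatter) lies within the scatter. Compound 1 `N#CC1CN1C(=O)Nc1ccc(F)cc1` gives 3400 nM, and the step of a 3.2-fold higher number from compound 1 to compound 3 (0.51 log units; beyond the scatter) lies beyond it. Compound 4 `N#CC1CN1C(=O)Nc1ccc(S(N)(=O)=O)cc1` differs from compound 3 by sulfamoyl in place of hydrogen on an aromatic carbon. The two measured steps both bear on this change, since each removes a group from an aromatic carbon to reach compound 3; one was modest and beyond the scatter, the other within it. Going the other way, adding a group there, a modest drop in the number is expected, about a 2.0-fold lower number from compound 3 to compound 4 (0.30 log units; within the scatter). Compound 4 is therefore estimated at 5500 nM, within a range from 2000 nM to 15000 nM.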

Compound 4, half-maximal inhibitory concentration: 188000 nM
Compound 4: middle estimate off by 34-fold (1.53 log units), on the low side; measured number outside the range, above it.
By their numbers in this assay, from the lowest: compounds 1, 2 and 3 (each within the scatter of the next, the first and the last beyond it); then compound 4.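

Sulfamoyl shows that this aromatic carbon does not treat all groups alike: in this assay, fluoro gave a lower number than hydrogen and ethoxycarbonyl stayed within the scatter of it, whereas sulfamoyl gives a 17-fold higher number from compound 3 to compound 4 (1.23 log units; beyond the scatter). The loss of strength is also large against the two substituted compounds, with a 32-fold higher number from compound 2 to compound 4 (1.51 log units; beyond the scatter) and a 55-fold higher number from compound 1 to compound 4 (1.74 log units; beyond the scatter). Nothing available here gives a reason for this loss. From the compounds shown here alone, how an amine or a carboxylic acid would behave at this carbon stays open, so it is unclear whether the loss is peculiar to sulfamoyl or shared with other groups.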